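Carboxyphenyl Replaces Carboxyethyl at the Aromatic Nitrogen

The source may report more compounds than this note shows. Statements on the series, on what has been measured and on what is new or still open speak of the compounds shown alone.

Within the data shown here, compound 2 `CCCCCCCCc1ccc(OCC(=O)COc2ccc3c(c2)cc(C(=O)O)n3CCCC(=O)O)cc1` gives 30 ug/mL in a physicochemical assay for solubility, in phosphate buffer, at pH 7.4 (on this read-out higher numbers stand for higher solubility and lower numbers for lower solubility), the only number among the values shown. For compound 1 `CCCCCCCCc1ccc(OCC(=O)COc2ccc3c(c2)cc(C(=O)O)n3CCCCCC)cc1` this assay reports only a limit, < 1 ug/mL, namely (the limit of < 1 ug/mL in this assay, at which 1 of the 2 values shown sits). Among the measured compounds shown here, the one measured step is an at least 30-fold higher number from compound 1 to compound 2 (1.47 log units; beyond the scatter). Compound 3 `CCCCCCCCc1ccc(OCC(=O)COc2ccc3c(c2)cc(C(=O)O)n3Cc2ccc(C(=O)O)cc2)cc1` differs from compound 2 by 4-carboxyphenyl in place of 2-carboxyethyl on a saturated chain carbon bound to an aromatic nitrogen. The carboxy that the measured step introduced is kept, but the chain gives way to a ring, so a downward move is expected, a 3.0-fold lower number from compound 2 to compound 3 (0.48 log units; beyond the scatter), smaller than the measured gain. Compound 3 is therefore expected to give 10 ug/mL, between 2 ug/mL and 40 ug/mL.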

Compound 3, solubility: 13 ug/mL
Beside the measured number, compound 3's estimate is 1.3-fold (0.11 log units) below it; low and high end bracket the measured number.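

In this assay, 4-carboxyphenyl in place of 2-carboxyethyl on a saturated chain carbon bound to an aromatic nitrogen gives a 2.3-fold lower number from compound 2 to compound 3 (0.36 log units; beyond the scatter), a modest step down. Set against the pentyl group, the same 4-carboxyphenyl gives an at least 13-fold higher number from compound 1 to compound 3 (1.11 log units; beyond the scatter), so among these compounds a carboxy carried on a ring, and not only one on a chain, goes with the higher number. Compound 1 stands at a limit and not at a number: the limit of < 1 ug/mL in this assay, at which 1 of the 3 values shown sits.

The compounds shown do not separate the ring itself from the added heavy atoms. Going by these compounds, whether an amine or a sulfonic acid would serve here as the carboxy does remains open.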